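This account rests on a few compounds, and the source may have more. Where it says the series, first, only, none or still open, it means among the compounds named here.

Measured compounds: compound 1 `O=C1C[C@H]2O[C@H]([C@H](O)c3ccccc3)[C@H](O)[C@H]2O1` gives 32500 nM; compound 2 `CO[C@@H](c1ccccc1)[C@H]1O[C@@H]2CC(=O)O[C@@H]2[C@H]1O` gives 12600 nM; compound 3 `CO[C@H](c1ccccc1)[C@H]1O[C@@H]2CC(=O)O[C@@H]2[C@H]1O` gives 15600 nM, all in a functional assay on Jurkat cells (Homo sapiens) for inhibition, read by MTT assay, with a stated time of 72 h; a lower number here means a stronger inhibitor, a higher number a weaker inhibitor.

Compound 1 and compound 3 differ by one change, (methyl in place of hydrogen on an oxygen on a saturated carbon), and the step was a 2.1-fold lower number from compound 1 to compound 3 (0.32 log units; beyond the scatter). Compound 2 and compound 3 are related by the fact that compounds 2 and 3 differ only in the configuration as drawn, and the step of a 1.2-fold higher number from compound 2 to compound 3 (0.09 log units; within the scatter) shows the two values within the scatter of each other. The difference between the core of compound 1 and the core of compound 2 is not broken down here.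

Compound 4 `CO[C@@H]1[C@H]2OC(=O)C[C@H]2O[C@@H]1[C@@H](OC)c1ccccc1` is not yet measured in this assay. It differs from compound 2 by methyl in place of hydrogen on an oxygen on a saturated carbon. This is the same kind of change as that from compound 1 to compound 3, but the place is not identical: in the earlier pair the oxygen sits on a saturated carbon whose other neighbour is a saturated chain carbon, whereas in compound 4 the other neighbour is a saturated ring carbon. Resting on compound 2 at 12600 nM and on the earlier step of a 2.1-fold lower number from compound 1 to compound 3 (0.32 log units; beyond the scatter), the expected step is a 1.7-fold lower number from compound 2 to compound 4 (0.23 log units; within the scatter). Compound 4 is therefore estimated at 7500 nM, with a likely range from 3500 nM to 16000 nM.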

Compound 4, half-maximal inhibitory concentration: 1690 nM
Beside the measured number, compound 4's estimate is 4.4-fold (0.65 log units) above it; measured number below the stated range.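

In this assay, methyl in place of hydrogen on an oxygen on a saturated carbon whose other neighbour is a saturated ring carbon gave a 7.5-fold lower number from compound 2 to compound 4 (0.87 log units; beyond the scatter), and set beside the earlier case, the same kind of change lowered the number on both cores but not by a single amount: the same change on two cores in this assay, a 2.1-fold lower number (0.32 log units; beyond the scatter) from compound 1 to compound 3 and a 7.5-fold lower number (0.87 log units; beyond the scatter) from compound 2 to compound 4, 3.6-fold (0.55 log units) apart, beyond the scatter of two such steps The direction therefore held in these two cases, while the size did not carry over from one core to the other. The two steps do not show whether the gap comes from the core or from the place of the change, as the oxygen's other neighbour is a saturated chain carbon in the earlier pair and a saturated ring carbon in the new one, and two steps establish no general rule for this series.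

The compounds shown leave open how an ethoxy group or an amine in place of the methoxy on that saturated ring carbon would read. They also leave open whether the size of the new step depends on the methoxy already present on the saturated chain carbon.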